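Methyl on the Ring Nitrogen of a Weaker Antiproliferative

The source may report more compounds than this note shows. Statements on the series, on what has been measured and on what is new or still open speak of the compounds shown alone.

Compound 1 `O=C(Nc1ccc(Oc2ccnc3[nH]ccc23)c(F)c1)c1cc2cccnc2n(-c2ccc(Br)cc2)c1=O`: 120 nM
Compound 2 `O=C(Nc1ccc(Oc2ccnc3[nH]ccc23)c(F)c1)c1cc2cccnc2n(-c2ccc(C(F)(F)F)cc2Cl)c1=O`: 1360 nM

In a functional assay on HT-29 cells (Homo sapiens) for antiproliferative activity, read by MTT assay, with a stated time of 72 h (a lower number here means a stronger inhibitor, a higher number a weaker inhibitor), compound 2 gives 1360 nM, the highest of the two numbers. Among the compounds with values here, compound 1 gives 120 nM, and the single measured step is an 11-fold higher number from compound 1 to compound 2 (1.05 log units; beyond the scatter). Compound 3 `Cn1ccc2c(Oc3ccc(NC(=O)c4cc5cccnc5n(-c5ccc(C(F)(F)F)cc5Cl)c4=O)cc3F)ccnc21` differs from compound 2 by methyl in place of hydrogen on an aromatic nitrogen. Within the data shown here, the measured step changed an aryl group on another aromatic nitrogen, so it says nothing about adding a methyl here, and no other step bears on this change. The expected step is therefore a 1.1-fold higher number from compound 2 to compound 3 (0.04 log units; within the scatter), within the scatter. The estimate for compound 3 is 1500 nM, between 500 nM and 4500 nM.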

Compound 3, half-maximal inhibitory concentration: 5830 nM
For compound 3 the middle estimate is 3.9-fold (0.59 log units) below the measured one, outside the stated range (above it).
By their numbers in this assay, from the lowest: compound 1; then compound 2; then compound 3.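

In this assay, replacing the hydrogen on the aromatic nitrogen of the five-membered ring with methyl gives a 4.3-fold higher number from compound 2 to compound 3 (0.63 log units; beyond the scatter) and so makes the compound weaker, a modest step. This shows that the number responds to a change at this nitrogen, even one as small as methyl. Nothing available explains this loss.

An ethyl group or a longer chain ending in an amine on this nitrogen could still move the number either way. Going by these compounds, whether methyl here has the same effect with the 4-bromophenyl group of compound 1 also remains open.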